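Dropping the amino group from compound 1

A few compounds are considered here, and "the series" means these few. Any claim that something is new, unique, unknown or untested is made for them only; others in the source may bear on it.

Measured compounds:
- compound 1 `Nc1nc(Cl)c2ncn(Cc3ccccc3CCl)c2n1`: 67600 nM
- compound 2 `ClCc1ccccc1Cn1cnc2nc(Cl)nc(Cl)c21`: 2570 nM
- compound 3 `Nc1nc(Cl)c2ncn(Cc3cccc(CCl)c3)c2n1`: 25100 nM

These three compounds were tested in a functional assay on PC-3 cells (Homo sapiens) for cytotoxicity, read by sulforhodamine B assay, with a stated time of 48 h (a higher number here means a weaker inhibitor of growth, a lower number a stronger inhibitor of growth), a cell-based measure of how strongly a substance stops prostate cancer cells from growing. Compound 1 has the highest number of the three, which here means the weakest growth inhibition. Its nearest neighbour is compound 3, whose value lies beyond the usual scatter of repeated measurements, and the gap to compound 2 is wider still.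

The next compound, compound 4 `ClCc1ccccc1Cn1cnc2c(Cl)ncnc21`, has not yet been measured in this assay. It differs from compound 1 in one place: hydrogen in place of amino on an aromatic carbon. For the measured compounds named here, no two measured compounds differ from each other in just one place, so no directly comparable step is available. Going by the values given here, the values of compound 1 and compound 2 show that changing the group at this part of the core can move the number a long way downward, but no measured pair tells what hydrogen in particular does there.

On this basis, compound 4 is expected to inhibit growth more strongly than compound 1, by a step estimated as a 4.5-fold lower number from compound 1 to compound 4 (0.65 log units; beyond the scatter). The estimated value for compound 4 is 15000 nM, with a plausible range from 3000 nM to 60000 nM.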

Compound 4, concentration for total growth inhibition: 10500 nM
Compound 4: middle estimate off by 1.4-fold (0.15 log units), on the high side; the measured number falls inside the stated range.
By their numbers in this assay, from the lowest: compound 2; then compound 4; then compound 3; then compound 1.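

For the compounds shown here, compound 4 gives the first comparison in which only one thing changes: the amino group on the aromatic carbon between two ring nitrogen atoms gives way to hydrogen, and the rest of compound 1 stays the same. In this assay, this swap brings a 6.4-fold lower number from compound 1 to compound 4 (0.81 log units; beyond the scatter), so growth inhibition becomes stronger without the amino group, and that group is not needed for compound 4 to act on these cells. The change in the number can now be tied to this single position rather than read loosely from compounds that differ in more than one place, but nothing measured here explains the gain.

Hydrogen is the only replacement for amino shown here, so it remains open what a methyl group, a hydroxyl group or a dimethylamino group would do on this same carbon, and whether the number depends on the group's size or on some other feature. It also remains open whether the same swap would move the number to a similar extent in compound 3, the other compound shown that carries this amino group.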